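Swapping the pyrazole for a triazole on a CXCR3 antagonist

The source may report more compounds than this note shows. Statements on the series, on what has been measured and on what is new or still open speak of the compounds shown alone.

Three compounds share one core and differ only in the five-membered ring attached to the chain carbon next to the carbonyl. In a functional assay on CHO-K1 cells for antagonist activity at C-X-C chemokine receptor type 3 (Homo sapiens), read by FLIPR, with a stated time of 10 min (a lower number here means a stronger inhibitor, a higher number a weaker inhibitor), compound 1 `CCOc1ncc(-c2nc(C(F)(F)F)sc2N2CCN(C(=O)Cn3ncc4cccnc43)[C@H](C)C2)cn1` gives 4.1 nM, compound 2 `CCOc1ncc(-c2nc(C(F)(F)F)sc2N2CCN(C(=O)Cn3nc(C)cc3C)[C@H](C)C2)cn1` gives 2.3 nM and compound 3 `CCOc1ncc(-c2nc(C(F)(F)F)sc2N2CCN(C(=O)Cn3ccc(C(F)(F)F)n3)[C@H](C)C2)cn1` gives 3.8 nM. Compound 3 sits second highest of these three numbers, but every gap is small: a 1.1-fold lower number from compound 1 to compound 3 (0.03 log units; within the scatter), a 1.8-fold lower number from compound 1 to compound 2 (0.25 log units; within the scatter) and a 1.7-fold higher number from compound 2 to compound 3 (0.22 log units; within the scatter). Compound 4 `CCOc1ncc(-c2nc(C(F)(F)F)sc2N2CCN(C(=O)Cn3cnc(C(F)(F)F)n3)[C@H](C)C2)cn1` carries 3-(trifluoromethyl)-1H-1,2,4-triazol-1-yl in place of 3-(trifluoromethyl)-1H-pyrazol-1-yl on a saturated chain carbon bound to a carbonyl carbon. Within the data shown here, no measured step tests exactly this swap, yet all three ring changes left this assay essentially unmoved, so the expectation for compound 4 is a 1.2-fold higher number from compound 3 to compound 4 (0.07 log units; within the scatter). Compound 4 is therefore estimated at 4.5 nM, with a range of 1.5 nM to 13 nM.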

Compound 4, half-maximal inhibitory concentration: 3.8 nM
Estimate against measurement, compound 4: 1.2-fold (0.07 log units) above; low and high end bracket the measured number.
By their numbers in this assay, from the lowest: compounds 2, 3, 4 and 1 (each within the scatter of the next).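

Setting 3-(trifluoromethyl)-1H-1,2,4-triazol-1-yl in place of 3-(trifluoromethyl)-1H-pyrazol-1-yl on the saturated chain carbon bound to a carbonyl carbon is the first test of an extra ring nitrogen and hydrogen-bond acceptor here, and this assay gives no change at the digits printed from compound 3 to compound 4 (within the scatter). The triazole also cannot be told apart from the other two rings, with a 1.7-fold higher number from compound 2 to compound 4 (0.22 log units; within the scatter) and a 1.1-fold lower number from compound 1 to compound 4 (0.03 log units; within the scatter). No evidence is available to explain this result. All the groups shown at this place are aromatic rings, so an open-chain amine or a carboxylic acid there remains an open question.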